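Removing the methyl ortho to the sulfonamide in compound 3

The source may hold more compounds than are shown below. What is called first, only, known or untested is meant among the compounds shown, and "the series" means these compounds.

Compound 3 `Cc1ccc(NS(=O)(=O)c2ccc(N3CCNC3=O)cc2)c(C)c1` gives 180 nM in a functional assay on HT-29 cells (Homo sapiens) for antiproliferative activity, read by sulforhodamine B assay, with a stated time of 48 h (on this read-out higher numbers stand for weaker inhibition and lower numbers for stronger inhibition), the lowest of the two numbers recorded so far. Nearest to it is compound 1 `COc1ccccc1NS(=O)(=O)c1ccc(N2CCNC2=O)cc1`, which in this assay gives 550 nM. Compound 2 `CCCCCCOc1ccc(NS(=O)(=O)c2ccc(N3CCNC3=O)cc2)cc1` reaches only the limit of this assay, > 1000 nM, which is a limit and not a number (the limit of > 1000 nM in this assay, at which 1 of the 3 values shown sits). For the measured compounds named here, the single measured step is that from compound 1 to compound 3, a 3.1-fold lower number from compound 1 to compound 3 (0.49 log units; beyond the scatter), with 2,4-dimethylphenyl in place of 2-methoxyphenyl on a sulfonamide nitrogen.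

Compound 4 `Cc1ccc(NS(=O)(=O)c2ccc(N3CCNC3=O)cc2)cc1` differs from compound 3 by hydrogen in place of methyl on an aromatic carbon; cut one bond further out, the change reads 2,4-dimethylphenyl to 4-methylphenyl. Going by the values given here, no measured step removes this methyl on its own: the one step recorded alters the group on the sulfonamide nitrogen at two places at once, so the share of the methyl ortho to the large group cannot be separated from it. The removal of a single methyl is therefore expected to give at most a modest weakening in this assay, a step of a 1.7-fold higher number from compound 3 to compound 4 (0.22 log units; within the scatter), which may well stay within the scatter. Compound 4 is estimated at 300 nM, with a range from 150 nM to 800 nM.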

Compound 4, half-maximal inhibitory concentration: 480 nM
Compound 4: the middle estimate sits 1.6-fold (0.20 log units) below what was measured, within the range that was stated.
By their numbers in this assay, from the lowest: compound 3; then compounds 4 and 1 (each within the scatter of the next). At a limit, above all of these: compound 2.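

In this assay, the methyl ortho to a large group now has a step of its own, a 2.7-fold higher number from compound 3 to compound 4 (0.43 log units; beyond the scatter), whereas the earlier step changed the group on the sulfonamide nitrogen at two places at once. That single step is close in size to a 3.1-fold lower number from compound 1 to compound 3 (0.49 log units; beyond the scatter), and once the methyl is gone the difference from the 2-methoxyphenyl group falls inside the scatter, a 1.1-fold lower number from compound 1 to compound 4 (0.06 log units; within the scatter), so within these compounds the lower number of compound 3 goes with this one methyl. Methyl in place of hexyloxy also reads as a step, an at least 2.0-fold lower number from compound 2 to compound 4 (0.31 log units; beyond the scatter), but its size is only a bound, since compound 2 stands at a limit and not at a number: the limit of > 1000 nM in this assay, at which 1 of the 4 values shown sits.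

Going by these compounds, whether an ethyl group, a chlorine atom or a methoxy group at the place ortho to a large group would keep the number of compound 3 or lose it stays open. On these data alone, the share of the remaining methyl in the 4-methylphenyl group is equally open, as is how a hydroxyl group or an amine would read in its place.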